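Acetyl for Methyl on an Aromatic Nitrogen

A few compounds are considered here, and "the series" means these few. Any claim that something is new, unique, unknown or untested is made for them only; others in the source may bear on it.

Compound 1, `Cn1ncc2cc(NC(=O)NCc3cc(C(F)(F)F)nn3-c3cccc(Cl)c3)ccc21`, gives 61 nM in an assay on CHO-K1 cells for antagonist activity at transient receptor potential cation channel subfamily V member 1 (Homo sapiens), read by FLIPR and calcium flux, with a stated time of 6 min; on this read-out lower numbers stand for stronger inhibition and higher numbers for weaker inhibition.
Compound 2, `O=C(NCc1cc(C(F)(F)F)nn1-c1cccc(Cl)c1)Nc1cccc2[nH]ncc12`, gives 0.9 nM in this assay.
Compound 3, `Cn1ncc2c(NC(=O)NCc3cc(C(F)(F)F)nn3-c3cccc(Cl)c3)cccc21`, gives 2.3 nM in this assay.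

Among these three, compound 3 stands second, with only compound 2 showing a lower number: a 2.6-fold higher number from compound 2 to compound 3 (0.41 log units; beyond the scatter). Compound 1 is far weaker, as a 27-fold lower number from compound 1 to compound 3 (1.42 log units; beyond the scatter) shows.

Compound 4, `CC(=O)n1ncc2c(NC(=O)NCc3cc(C(F)(F)F)nn3-c3cccc(Cl)c3)cccc21`, differs from compound 3 in one spot: acetyl in place of methyl on an aromatic nitrogen. Among the compounds with values here, no measured pair swaps a methyl for an acetyl, so the only step that bears on it is the one on the same nitrogen, a 2.6-fold higher number from compound 2 to compound 3 (0.41 log units; beyond the scatter), which was modest. The large steps of a 68-fold lower number from compound 1 to compound 2 (1.83 log units; beyond the scatter) and a 27-fold lower number from compound 1 to compound 3 (1.42 log units; beyond the scatter) concern a different change and give no guide here. A modest step is therefore expected in this assay, more likely toward a higher number than a lower one, but not with confidence beyond the scatter.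

Compound 4 is estimated at 5 nM, within 1.5 nM to 20 nM, corresponding to an expected 2.2-fold higher number from compound 3 to compound 4 (0.34 log units; beyond the scatter).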

Compound 4, inhibition constant: 17.4 nM
Estimate against measurement, compound 4: 3.5-fold (0.54 log units) below; low and high end bracket the measured number.
By their numbers in this assay, from the lowest: compound 2; then compound 3; then compound 4; then compound 1.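

At this aromatic nitrogen, this assay now compares three groups, and the number rises with each one: hydrogen, then methyl, then acetyl. Acetyl in place of methyl gives a 7.6-fold higher number from compound 3 to compound 4 (0.88 log units; beyond the scatter), and acetyl in place of hydrogen gives a 19-fold higher number from compound 2 to compound 4 (1.29 log units; beyond the scatter), so the position that accepted methyl at a modest cost loses much more of the inhibition when it carries acetyl. No measurement shown here explains why this change weakens inhibition.

The compounds shown leave open whether the rise follows the added carbon atoms or the carbonyl of the acetyl group, which brings the only hydrogen-bond acceptor of the three groups. An ethyl group on the same nitrogen, with carbon but no oxygen, would help to tell these two apart.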